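Moving the Amine Along the Chain in Compound 4

The source may hold more compounds than are shown below. What is called first, only, known or untested is meant among the compounds shown, and "the series" means these compounds.

Compound 2 `CC(C)C[C@@H](N)CN(C(=O)[C@@H]1C[C@H]1c1ccccc1)c1ccc(-c2ccccc2)cc1` gives 1.8 nM in a functional assay for agonist activity at G protein-coupled receptor 88 (Homo sapiens), read by HTRF and cAMP accumulation; on this read-out lower numbers stand for an effect already at smaller amounts and higher numbers for an effect only at larger amounts of compound. It holds the highest of the two numbers; compound 3 `N[C@@H](CC1CCCCC1)CN(C(=O)[C@@H]1C[C@H]1c1ccccc1)c1ccc(-c2ccccc2)cc1` gives 1.7 nM, and the step of a 1.1-fold lower number from compound 2 to compound 3 (0.02 log units; within the scatter) lies within the scatter. Compound 1 `CC(C)CCCN(C(=O)[C@@H]1C[C@H]1c1ccccc1)c1ccc(-c2ccccc2)cc1` reaches only a limit, > 100 nM. Compound 4 `CCC(C)CNCCN(C(=O)[C@@H]1C[C@H]1c1ccccc1)c1ccc(-c2ccccc2)cc1` differs from compound 2 by ((2-methylbutyl)amino)methyl in place of 1-amino-3-methylbutyl on a saturated chain carbon bound to an amide-type nitrogen. The step of an at least 55-fold lower number from compound 1 to compound 2 (1.74 log units; beyond the scatter) accompanies the addition of the amino group, while a 1.1-fold lower number from compound 2 to compound 3 (0.02 log units; within the scatter) shows the alkyl tail to be interchangeable. Compound 4 keeps a hydrogen-bond donor and acceptor but loses the defined stereocentre, so a moderate rise in this assay is expected, a 6.7-fold higher number from compound 2 to compound 4 (0.82 log units; beyond the scatter). Compound 4 is therefore estimated at 12 nM, within 3 nM to 50 nM.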

Compound 4, half-maximal effective concentration: 4.7 nM
Beside the measured number, compound 4's estimate is 2.6-fold (0.41 log units) above it; the measured number falls inside the stated range.
By their numbers in this assay, from the lowest: compounds 3 and 2 (each within the scatter of the next); then compound 4. At a limit, above all of these: compound 1.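

Placing the nitrogen inside the chain, as in ((2-methylbutyl)amino)methyl, keeps most of the effect in this assay, even with the defined stereocentre gone: the cost is only modest, with a 2.6-fold higher number from compound 2 to compound 4 (0.42 log units; beyond the scatter) and a 2.8-fold higher number from compound 3 to compound 4 (0.44 log units; beyond the scatter). The gain over the chain without nitrogen remains large, with an at least 21-fold lower number from compound 1 to compound 4 (1.32 log units; beyond the scatter). Compound 1 stays at a limit: the limit of > 100 nM in this assay, at which 1 of the 4 values shown sits.

The change alters the place of the nitrogen and removes the stereocentre at once, and the two effects cannot be separated here. As far as these compounds go, how a tertiary amine or an ether oxygen would read at this place remains open.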